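The source may hold more compounds than are shown below. What is called first, only, known or untested is meant among the compounds shown, and "the series" means these compounds.

Working notes on the series. The shared core is seen in compound 1 `O=c1ccoc2cc(OCc3cn(Cc4ccc(Cl)cc4Cl)nn3)ccc12`, which in a functional assay on HeLa cells (Homo sapiens) for cytotoxicity, read by MTT assay, with a stated time of 48 h (a higher number here means a weaker inhibitor, a lower number a stronger inhibitor), gives 80600 nM. Compound 2 `O=c1ccoc2cc(OCc3cn(Cc4ccccc4Cl)nn3)ccc12` is the nearest measured neighbour of the new compound. In this assay compound 2 reports > 100000 nM, and this figure is a limit of the assay rather than a number. Going by the values given here, the only measured step in the set, an at least 1.2-fold higher number from compound 1 to compound 2 (0.09 log units; that floor lies within the scatter), alters the benzyl region, and its floor sits within the usual scatter; it is bounded by the limit of > 100000 nM in this assay, at which 1 of the 2 values shown sits. Compound 3 `N#Cc1ccc(Cn2cc(COc3ccc4c(=O)ccoc4c3)nn2)cc1` changes the same region of compound 2: 4-cyanophenyl in place of 2-chlorophenyl on a saturated chain carbon bound to an aromatic nitrogen. Among the compounds with values here, no measured step of this kind exists here, and the one neighbour sits at the limit. Accordingly no change beyond the scatter is expected in this assay, and compound 3 is expected to remain at or near the upper limit of the assay. The estimated step is a step that the limit leaves unreadable from compound 2 to compound 3. For compound 3 the estimate is 110000 nM, within 45000 nM to 300000 nM, with a fair chance that only a limit is returned once more.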

Compound 3, half-maximal inhibitory concentration: > 100000 nM
Compound 3: only a limit was reported; the forecaster's own chance of this, stated with the estimate: 60%; the middle value is on the limit's open side.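

In this assay compound 3 gives > 100000 nM, which is a limit of the assay and not a number. Placing 4-cyanophenyl where compound 1 carries 2,4-dichlorophenyl gives an at least 1.2-fold higher number from compound 1 to compound 3 (0.09 log units; that floor lies within the scatter), so the nitrile-bearing ring yields no readable change from compound 1 and only a floor on its size. The step from 2-chlorophenyl to 4-cyanophenyl cannot be read, and a second, different aryl group on the saturated chain carbon bound to an aromatic nitrogen now ends at the limit: the limit of > 100000 nM in this assay, at which 2 of the 3 values shown sit.

As far as these compounds go, the order of compound 2 and compound 3 stays open, as does whether any group at this position can give a value clearly lower than that of compound 1. Also open, from the compounds shown here alone, is whether an amine or a carboxylic acid on the phenyl ring, or a longer chain in place of the benzyl carbon, would return a number rather than a limit in this assay.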